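Shortening a Selenium-Bearing Chain in Two Different Settings

A few compounds are considered here, and "the series" means these few. Any claim that something is new, unique, unknown or untested is made for them only; others in the source may bear on it.

Four compounds share one core and carry a side chain ending in a selenium-bearing group. Compound 1 `COc1ccc(N(C)c2nc(C)nc3ccccc23)cc1OCCC[Se]C#N` and compound 2 `COc1ccc(N(C)c2nc(C)nc3ccccc23)cc1OCC[Se]C#N` were both tested in a functional assay on LoVo cells (Homo sapiens) for inhibition, read by MTT assay, with a stated time of 48 h; on this read-out lower numbers stand for stronger inhibition and higher numbers for weaker inhibition. Compound 1 gives 921 nM, whereas compound 2 gives 19 nM. The change between them is a group of 3 heavy atoms (1 carbon, 1 nitrogen, 1 selenium; no ring) in place of a group of 4 heavy atoms (2 carbon, 1 nitrogen, 1 selenium; no ring), on a saturated chain carbon, two bonds along the chain from an oxygen on an aromatic ring, and it made the step of a 48-fold lower number from compound 1 to compound 2 (1.69 log units; beyond the scatter). Compound 3 `COc1ccc(N(C)c2nc(C)nc3ccccc23)cc1C(=O)OCCCCCC[Se]C#N` carries its chain in a different way; in this assay compound 3 gives 1050 nM. The difference between the core of compound 1 and the core of compound 3 is not broken down here, so only their values can be compared: compound 3 and compound 1 lie within the scatter of each other, and both sit far from compound 2.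

Compound 4 `COc1ccc(N(C)c2nc(C)nc3ccccc23)cc1C(=O)OCCCCC[Se]C#N` has not yet been measured. It differs from compound 3 by a group of 3 heavy atoms (1 carbon, 1 nitrogen, 1 selenium; no ring) in place of a group of 4 heavy atoms (2 carbon, 1 nitrogen, 1 selenium; no ring), on a saturated chain carbon, five bonds along the chain from an oxygen next to a carbonyl group. This is the same kind of change as that from compound 1 to compound 2, but the surroundings differ: there the change sat two bonds along the chain from an oxygen on an aromatic ring, here it sits five bonds along the chain from an oxygen next to a carbonyl group. Because the earlier step of a 48-fold lower number from compound 1 to compound 2 (1.69 log units; beyond the scatter) was large, some improvement is expected, but a single example in a different setting gives limited confidence, so the step from compound 3 to compound 4 is estimated at a 3.0-fold lower number from compound 3 to compound 4 (0.48 log units; beyond the scatter). In this assay compound 4 is expected to give 350 nM, likely between 60 nM and 1500 nM.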

Compound 4, half-maximal inhibitory concentration: 714 nM
Compound 4: the middle estimate sits 2.0-fold (0.31 log units) below what was measured; the measured number falls inside the stated range.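

In this assay, shortening the chain on the core of compound 3 gives a 1.5-fold lower number from compound 3 to compound 4 (0.17 log units; within the scatter), so on this core the swap produces no difference that can be told apart from ordinary repeat-to-repeat variation. The same structural change therefore does not carry over at the same size from one core to the other, and the gap between the two steps is real rather than noise: the same change on two cores in this assay, a 48-fold lower number (1.69 log units; beyond the scatter) from compound 1 to compound 2 and a 1.5-fold lower number (0.17 log units; within the scatter) from compound 3 to compound 4, 33-fold (1.52 log units) apart, beyond the scatter of two such steps

For the compounds shown here, this does not show which feature of the setting decides the size of the step, since there is only one pair on each core, and the two pairs differ in several ways at once: one change sits two bonds along the chain from an oxygen on an aromatic ring, the other five bonds along the chain from an oxygen next to a carbonyl group.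

The compounds shown leave open whether a still shorter chain on the core of compound 3 would bring a step as large as the one seen on the core of compound 1. They also leave open whether an amide link in place of the carbonyl-and-oxygen link, or a thiocyanate in place of the selenium-bearing end group, would behave the same way.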